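Swapping Ethyl for Trifluoromethoxy on a Fused Core

A few compounds are considered here, and "the series" means these few. Any claim that something is new, unique, unknown or untested is made for them only; others in the source may bear on it.

Three compounds share a fused core joined to a second aromatic ring. Compound 1 `N#Cc1ccccc1-c1ccc2[nH]ncc2c1` carries a nitrile on that outer ring; in an assay on CHO-TREX cells for antagonist activity at transient receptor potential cation channel subfamily A member 1 (Homo sapiens), read by FLIPR and calcium flux, with a stated time of 10 min (a lower number here means a stronger inhibitor, a higher number a weaker inhibitor), compound 1 gives 1290 nM. Compound 2 `Cc1cc(-c2ccccc2C(F)(F)F)cc2cn[nH]c12` carries a trifluoromethyl on the outer ring and a methyl on the core, and in this assay compound 2 gives 6720 nM. Compound 3 `CCc1cc2[nH]ncc2cc1-c1ccccc1C(F)(F)F` keeps the trifluoromethyl and carries an ethyl on the core; in this assay compound 3 gives 50 nM, the lowest of the three numbers and so the strongest inhibitor shown here. Compound 1 sits well above it and compound 2 further still, both gaps lying beyond the scatter of repeated measurements.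

Compound 4 `FC(F)(F)Oc1cc2[nH]ncc2cc1-c1ccccc1C(F)(F)F` has not yet been measured. It differs from compound 3 in one place: trifluoromethoxy in place of ethyl on an aromatic carbon. The ethyl leaves and the trifluoromethoxy enters at the same aromatic carbon of the six-membered carbon ring within the fused system. No measured pair shows this exact exchange, so there is no precedent among these compounds to lean on. A modest step is expected, a 2.2-fold higher number from compound 3 to compound 4 (0.34 log units; beyond the scatter), most likely a small weakening or none beyond the scatter. Compound 4 is therefore estimated at 110 nM, with a plausible range from 30 nM to 400 nM.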

Compound 4, half-maximal inhibitory concentration: 36 nM
Compound 4: middle estimate off by 3.1-fold (0.49 log units), on the high side; the range from low to high includes it.
By their numbers in this assay, from the lowest: compounds 4 and 3 (each within the scatter of the next); then compound 1; then compound 2.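

Going by these compounds alone, the first step between two compounds that differ in one place is trifluoromethoxy in place of ethyl, which gives a 1.4-fold lower number from compound 3 to compound 4 (0.14 log units; within the scatter) in this assay. On this aromatic carbon, ortho to a large group, the entering group has 5 heavy atoms against 2 for the ethyl and brings 1 hydrogen-bond acceptor where the ethyl has none, yet the two compounds cannot be told apart in this assay. The position therefore accepts two quite different groups with no change beyond the scatter, although nothing available explains why these two read alike.

As far as these compounds go, how an amine, a carboxylic acid or a longer chain such as butyl would read on this aromatic carbon remains open. From the compounds shown here alone, whether the low numbers depend on having any group here at all also stays open, and a plain hydrogen on this carbon with the trifluoromethyl kept on the outer ring would be the comparison that decides it.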